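The source may hold more compounds than are shown below. What is called first, only, known or untested is meant among the compounds shown, and "the series" means these compounds.

Measured so far:
compound 1 `COc1ccc(-c2nnc(CCSC(=S)NCc3cccnc3)o2)cc1` gives 1540 nM
compound 2 `S=C(NCc1cccnc1)SCCc1nnc(-c2cc[nH]c2)o1` gives 1170 nM

In a functional assay on Bel-7402 cells (Homo sapiens) for cytotoxicity, read by resazurin assay, with a stated time of 72 h (a lower number here means a stronger inhibitor, a higher number a weaker inhibitor), compound 2 gives 1170 nM and stands within the scatter of compound 1. Compound 3 `S=C(NCc1cccnc1)SCCc1nnc(-c2cccs2)o1` carries thiophen-2-yl in place of 1H-pyrrol-3-yl on an aromatic carbon is the whole difference from compound 2. Among the compounds with values here, the only measured step at this place (a 1.3-fold lower number from compound 1 to compound 2 (0.12 log units; within the scatter)) stays within the scatter, and it is the sole guide here. The expected step (a 1.1-fold higher number from compound 2 to compound 3 (0.05 log units; within the scatter)) therefore also stays within the scatter, with no direction favoured. Compound 3 is estimated at 1300 nM with 600 nM as the expected lower end and 2800 nM as the upper end.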

Compound 3, half-maximal inhibitory concentration: 1340 nM
For compound 3 the middle estimate is 1.0-fold (0.01 log units) below the measured one; low and high end bracket the measured number.
By their numbers in this assay, from the lowest: compounds 2, 3 and 1 (each within the scatter of the next).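

In this assay, thiophen-2-yl, which has no hydrogen-bond donor, stays within the scatter of 1H-pyrrol-3-yl, which has one (a 1.1-fold higher number from compound 2 to compound 3 (0.06 log units; within the scatter)). The comparison with 4-methoxyphenyl also stays within the scatter (a 1.1-fold lower number from compound 1 to compound 3 (0.06 log units; within the scatter)), so these three aromatic groups on this carbon cannot be told apart here. Nothing available explains this agreement.

On these data alone, it remains open whether an amine or a carboxylic acid at this place would give a step beyond the scatter. As far as these compounds go, the thioether chain and the pyridine end also remain open, as all three compounds share them.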